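Hydroxamate series: methyl for acetamido on the benzyl group

The source may report more compounds than this note shows. Statements on the series, on what has been measured and on what is new or still open speak of the compounds shown alone.

Measured compounds:
compound 1 `O=C(CCC1=CCCN(CCCCc2ccc(-c3ccccc3)cc2)C1=O)NO`, 4560 nM
compound 2 `CC(=O)Nc1ccc(CN2CCC=C(CCC(=O)NO)C2=O)cc1`, "not determined" (no result reported)

In a functional assay on HCT-15 cells (Homo sapiens) for inhibition, read by sulforhodamine B assay (a higher number here means a weaker inhibitor of growth, a lower number a stronger inhibitor of growth), compound 1 gives 4560 nM. Compound 2 has no single number in this assay, so its standing cannot be stated. Compound 3 `Cc1ccc(CN2CCC=C(CCC(=O)NO)C2=O)cc1` differs from compound 2 by methyl in place of acetamido on an aromatic carbon. For the measured compounds named here, no step between measured compounds exists for this change, so no direction beyond the scatter can be claimed in this assay. Compound 3 is expected near the level of compound 1, at an estimated 5000 nM with a range of 1500 nM to 20000 nM.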

Compound 3, concentration for 50% growth inhibition: 8510 nM
Compound 3: middle estimate off by 1.7-fold (0.23 log units), on the low side, and the stated range covers the measured number.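

For the compounds shown here, compound 2 has no single number in this assay and compound 3 at 8510 nM therefore yields no new step. The compounds shown leave open what methyl in place of acetamido does to growth inhibition in this assay here. No outside evidence bears on this result.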